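Two sulfonyl compounds at the limit, and a thiophene

The source may hold more compounds than are shown below. What is called first, only, known or untested is meant among the compounds shown, and "the series" means these compounds.

Measured in a functional assay on A549 cells (Homo sapiens) for inhibition, read by sulforhodamine B assay, with a stated time of 74 h; on this read-out higher numbers stand for weaker inhibition and lower numbers for stronger inhibition:
Compound 1 `CS(=O)(=O)N1C(=O)COC12C=CC(=O)C=C2`: > 10000 nM (a limit)
Compound 2 `O=C1C=CC2(C=C1)OCC(=O)N2S(=O)(=O)c1ccc(Cl)cc1`: > 10000 nM (a limit)

In this assay compound 2 stands at > 10000 nM, which is a limit and not a number. Compound 3 `O=C1C=CC2(C=C1)OCC(=O)N2S(=O)(=O)c1cccs1` differs from it in one place: thiophen-2-yl in place of 4-chlorophenyl on a sulfonyl sulfur. That is thiophen-2-yl in place of 4-chlorophenyl on a sulfonyl sulfur. Among the compounds with values here, the only measured step at this place, a step that the two limits leave unreadable from compound 1 to compound 2, has no readable size, so it offers neither a size nor a direction to carry over. Within the data shown here, the sole other evidence is the limit of > 10000 nM in this assay, at which 2 of the 2 values shown sit. Among the measured compounds shown here, no definite step is therefore expected in this assay, and compound 3 is expected to remain close to the limit. The expected step is a step that the limit leaves unreadable from compound 2 to compound 3. For compound 3 the estimate is 13000 nM, with an expected range of 4000 nM to 40000 nM.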

Compound 3, half-maximal inhibitory concentration: > 10000 nM
Compound 3: only a limit was reported (the forecaster's own chance of this, stated with the estimate: 70%); the middle value is on the limit's open side.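

In this assay, within the data shown here, compound 3 gives > 10000 nM, which is a limit and not a number, so no step from compound 1 or compound 2 to compound 3 can be read. The compounds shown leave open whether any group on the sulfonyl sulfur gives a measurable value in this assay.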